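One Group Swap Carried From Compound 2 to Compound 1

This account rests on a few compounds, and the source may have more. Where it says the series, first, only, none or still open, it means among the compounds named here.

Compound 1, `N#Cc1ccc(NC(=O)c2ccc(Cl)cc2O)cc1`, gives 1300 nM in a functional assay on HL-60 cells (Homo sapiens) for cytotoxicity, read by luminescence and CellTiter-Glo, with a stated time of 3 days; a higher number here means a weaker inhibitor, a lower number a stronger inhibitor.
Compound 2, `N#Cc1ccc(NC(=O)c2cc(F)ccc2O)cc1`, gives 1420 nM in this assay.
Compound 3, `O=C(Nc1ccc(C(F)(F)F)cc1)c1cc(F)ccc1O`, gives 490 nM in this assay.

Compound 1 and compound 2 differ in their cores, and the difference between the two cores is not broken down here. Their two numbers in this assay lie within the usual scatter of each other, so nothing separates them.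

Compound 3 differs from compound 2 in one place: trifluoromethyl in place of cyano on an aromatic carbon. That single change gave a 2.9-fold lower number from compound 2 to compound 3 (0.46 log units; beyond the scatter), a step that stands beyond the scatter of the measurement.

Compound 4, `O=C(Nc1ccc(C(F)(F)F)cc1)c1ccc(Cl)cc1O`, has not yet been measured in this assay. It is related to compound 1 exactly as compound 3 is related to compound 2: trifluoromethyl in place of cyano on an aromatic carbon. The description of the place is the same word for word in both pairs, so this is the same change made on a second core.

For the measured compounds named here, with only one measured example of the change, the expectation for compound 4 rests on that example alone: the step from compound 1 to compound 4 is expected to be a 2.9-fold lower number from compound 1 to compound 4 (0.46 log units; beyond the scatter), set beside a 2.9-fold lower number from compound 2 to compound 3 (0.46 log units; beyond the scatter). Because compound 1 gives 1300 nM, compound 4 is estimated at 450 nM, with a likely range from 200 nM to 1000 nM, the width allowing for the change to land somewhat differently on the core of compound 1.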

Compound 4, half-maximal inhibitory concentration: 630 nM
Compound 4: the middle estimate sits 1.4-fold (0.15 log units) below what was measured; the measured number falls inside the stated range.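

In this assay, putting trifluoromethyl in place of cyano on the core of compound 1 gave a 2.1-fold lower number from compound 1 to compound 4 (0.31 log units; beyond the scatter), so the change moved the number in the same direction on this second core as it did on the first. Set side by side, the two steps are close enough that the measurement cannot tell them apart, which means the size of the change also carried over between these two cores: the same change on two cores in this assay, a 2.9-fold lower number (0.46 log units; beyond the scatter) from compound 2 to compound 3 and a 2.1-fold lower number (0.31 log units; beyond the scatter) from compound 1 to compound 4, 1.4-fold (0.15 log units) apart, within the scatter of two such steps. For the compounds shown here, this is still only two matched pairs in a single cell assay, so it shows that the swap carried over here, but it does not show that it would do so on other cores or in other assays, and it does not explain why the number falls.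

The compounds shown leave open how other groups would behave at the same place on the aromatic ring, such as an amine, a carboxylic acid or a longer chain, since only cyano and trifluoromethyl appear there. They also leave open whether the step would hold on a core carrying a different group in place of the chlorine of compound 1, such as a methoxy group.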